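The compounds below may be only part of what the source reports. "The series", "measured", "known", "first", "only" and "open" are said of these compounds alone.

Measured so far in an ADME assay on HepG2 cells (Homo sapiens) for cytotoxicity, read by neutral red uptake, with a stated time of 48 h; a higher number here means a weaker inhibitor, a lower number a stronger inhibitor:
- compound 1 `Cc1cc(Cl)nc(NCCCCCCNc2ccnc3cc(Cl)ccc23)n1`: 8100 nM
- compound 2 `Cc1cc(NCCCCCCNc2ccnc3cc(Cl)ccc23)nc(N2CCCCC2)n1`: 6400 nM

Only these two compounds have numbers in this assay. Compound 2 gives 6400 nM and compound 1 gives 8100 nM, and the two values lie within the usual scatter of each other. Neither compound can be ranked above the other.

Next in the series is compound 3 `Cc1cc(NCCCCCCNc2ccnc3cc(Cl)ccc23)nc(Cl)n1`, reached from compound 2 by chloro in place of piperidin-1-yl on an aromatic carbon. The new chloro group sits between two ring nitrogen atoms, where compound 2 carries its piperidin-1-yl group.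

Among the compounds with values here, no measured pair differs in one place only, so no direct step is available as a guide. The nearest evidence is indirect: compound 1, which carries a chloro group, gives 8100 nM, while compound 2, which carries piperidin-1-yl, gives 6400 nM. On that basis, no change beyond the scatter is expected in this assay, with an estimated 1.1-fold higher number from compound 2 to compound 3 (0.04 log units; within the scatter). For compound 3 the expected value is 7000 nM, with an estimated range of 3000 nM to 16000 nM.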

Compound 3, half-maximal inhibitory concentration: 9100 nM
Beside the measured number, compound 3's estimate is 1.3-fold (0.11 log units) below it; the range from low to high includes it.
By their numbers in this assay, from the lowest: compounds 2, 1 and 3 (each within the scatter of the next).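

In this assay the position between two ring nitrogen atoms now has a direct one-place reading, with chloro in place of piperidin-1-yl (a 1.4-fold higher number from compound 2 to compound 3 (0.15 log units; within the scatter)). Exchanging a six-membered non-aromatic ring of 6 heavy atoms for a single chlorine therefore does not separate compound 2 from compound 3, and the size of the group entering here leaves no mark beyond the scatter across this pair. The exchange of 4-chloro-6-methylpyrimidin-2-yl for 2-chloro-6-methylpyrimidin-4-yl on the amine nitrogen reads the same way (a 1.1-fold higher number from compound 1 to compound 3 (0.05 log units; within the scatter)), and nothing measured here accounts for either result.

Open, as far as these compounds go, is whether any other group at this position, such as an amine, a morpholine ring or a carboxylic acid, would give a step beyond the scatter, since chloro and piperidin-1-yl alone cannot show how far the flat reading extends. Within the data shown here, also open is whether a shorter or longer chain in place of the one shared by compound 1, compound 2 and compound 3 would shift the number in this assay when the rest of the structure stays fixed.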